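Replacing chloromethyl with 2-(pyridin-4-yl)ethenyl on a carbonyl carbon

A few compounds are considered here, and "the series" means these few. Any claim that something is new, unique, unknown or untested is made for them only; others in the source may bear on it.

In a functional assay on A549 cells (Homo sapiens) for cytotoxicity, read by MTT assay, with a stated time of 48 h (a higher number here means a weaker inhibitor, a lower number a stronger inhibitor), compound 2 `C=C1C(=O)O[C@H]2CC3=C[C@H](C/C(C)=C/[C@@H](OC(=O)c4ccc(C(C)=O)cc4)[C@H]12)OC3=O` gives 2300 nM as a measured number. Compound 1 `C=C1C(=O)O[C@H]2CC3=C[C@H](C/C(C)=C/[C@@H](OC(=O)c4ccc(C(F)(F)F)cc4)[C@H]12)OC3=O` gives > 10000 nM as a limit of the assay. Compound 3 `C=C1C(=O)O[C@H]2CC3=C[C@H](C/C(C)=C/[C@@H](OC(=O)CCl)[C@H]12)OC3=O` gives > 10000 nM as a limit as well. Compound 3 thus stands at the limit of > 10000 nM in this assay, at which 2 of the 3 values shown sit, with compound 1 alongside it.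

Compound 4 `C=C1C(=O)O[C@H]2CC3=C[C@H](C/C(C)=C/[C@@H](OC(=O)/C=C/c4ccncc4)[C@H]12)OC3=O` keeps the same core and changes one group, and the difference reads 2-(pyridin-4-yl)ethenyl in place of chloromethyl on a carbonyl carbon in full: 2-(pyridin-4-yl)ethenyl in place of chloromethyl on a carbonyl carbon.

The closest measured change is an at least 4.3-fold higher number from compound 2 to compound 3 (0.63 log units; beyond the scatter) on going from 4-acetylphenyl to chloromethyl on that carbonyl carbon. Compound 2 therefore suggests that an aromatic group there can bring the number down. Compound 1 goes against any such rule, since it carries an aromatic group there and still sits at the limit. The step of an at least 4.3-fold lower number from compound 1 to compound 2 (0.63 log units; beyond the scatter) shows that the outcome depends on the substituent on the aromatic ring.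

A modest fall in the number is therefore expected, and a reading at the limit remains possible. The expected change is an at least 2.0-fold lower number from compound 3 to compound 4 (0.30 log units; that floor lies within the scatter) in this estimate. For compound 4 the estimated value is 5000 nM with an expected range from 1500 nM to 15000 nM in this assay here.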

Compound 4, half-maximal inhibitory concentration: 4000 nM
Estimate against measurement, compound 4: 1.3-fold (0.10 log units) above, and the stated range covers the measured number.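

Compound 4 shows that this carbonyl carbon can carry an aromatic group other than a substituted phenyl and still give a measured number in this assay: placing 2-(pyridin-4-yl)ethenyl there in place of chloromethyl gives an at least 2.5-fold lower number from compound 3 to compound 4 (0.39 log units; beyond the scatter), and placing it there in place of 4-(trifluoromethyl)phenyl gives an at least 2.5-fold lower number from compound 1 to compound 4 (0.39 log units; beyond the scatter). Set against the only other measured ester, the change gives a 1.7-fold higher number from compound 2 to compound 4 (0.24 log units; within the scatter), which lies within the scatter, so 2-(pyridin-4-yl)ethenyl and 4-acetylphenyl cannot be told apart in this assay, and an aromatic ring on this carbonyl carbon goes with a measured number in compound 2 and compound 4, while compound 1 goes against that pattern. Compound 1 and compound 3 now stand together at a value that is a limit of the assay, and compound 4 has left it: the limit of > 10000 nM in this assay, at which 2 of the 4 values shown sit.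

The compounds shown leave open whether the measured number in compound 4 belongs to the pyridine ring or to the double bond, which a 2-phenylethenyl group or a saturated 2-(pyridin-4-yl)ethyl group on the same carbonyl carbon would separate. They also leave open how an amine or a carboxylic acid on the aromatic ring would read.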